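Methyl to Chloro With No Number to Start From

The source may report more compounds than this note shows. Statements on the series, on what has been measured and on what is new or still open speak of the compounds shown alone.

Compound 1 (`COc1cccc(NC(=O)C(Cl)Cl)c1`) gives 54800 nM in a functional assay on Bel-7402 cells (Homo sapiens) for antiproliferative activity, read by MTT assay, with a stated time of 72 h (on this read-out higher numbers stand for weaker inhibition and lower numbers for stronger inhibition), and offers one reference point. Compound 2 (`O=C(Nc1cccc(SC(F)(F)F)c1)C(Cl)Cl`) gives 6540 nM in this assay and offers a second. Compound 3 (`Cc1ccc(NC(=O)C(Cl)Cl)cc1`) has no such standing: its result reads "not determined" (no result reported) in this assay and so cannot be ranked against the other two.

Compound 4 (`O=C(Nc1ccc(Cl)cc1)C(Cl)Cl`) differs from compound 3 in a single place. The difference is chloro in place of methyl on an aromatic carbon and amounts to chloro in place of methyl on an aromatic carbon.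

Within the data shown here, the only measured step is an 8.4-fold lower number from compound 1 to compound 2 (0.92 log units; beyond the scatter) for (trifluoromethyl)sulfanyl in place of methoxy on an aromatic carbon, a modest move beyond the scatter. It involves different groups, so it is only a loose guide to this swap. With no number for compound 3, the step to compound 4 cannot be sized directly, and the data settle no direction for it. A step no larger than the measured one is expected, and the estimate therefore draws on the span of the two measured values. Compound 4 is expected near 20000 nM with an estimated range of 6000 nM to 60000 nM once it is measured.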

Compound 4, half-maximal inhibitory concentration: 49600 nM
Compound 4: the middle estimate sits 2.5-fold (0.39 log units) below what was measured; the range from low to high includes it.
By their numbers in this assay, from the lowest: compound 2; then compounds 4 and 1 (each within the scatter of the next).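

Compound 3 has no number in this assay, so the step from it to compound 4, which gives 49600 nM, cannot be read. No supporting evidence bears on this result. The compounds shown leave open whether chloro in place of methyl on an aromatic carbon raises the number, lowers it, or leaves it within the scatter.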